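The source may hold more compounds than are shown below. What is called first, only, known or untested is meant among the compounds shown, and "the series" means these compounds.

Measured compounds:
- compound 1 `Oc1ccccc1-c1cc(-c2ccccc2)cc(-c2ccccc2O)n1`: compound 1 gives "not determined" (no result reported) in an assay on isolated protein for inhibition of DNA topoisomerase 1 (Homo sapiens), with a stated time of 30 min, tested at 20 uM; on this read-out lower numbers stand for a weaker effect and higher numbers for a stronger effect at the one concentration tested
- compound 2 `Oc1ccc(-c2cc(-c3ccccc3)cc(-c3ccccc3)n2)cc1`: compound 2 gives 43.6% in this assay
- compound 3 `Oc1cccc(-c2cc(-c3ccccc3)nc(-c3ccccc3)c2)c1`: compound 3 gives 0% in this assay

Compound 3 stands lowest of the two numbers obtained in this assay. Its nearest neighbour, compound 2, sits higher by an amount beyond the usual scatter, and compound 1 carries no number at all. Within the data shown here, no pair of measured compounds differs in a single place, so no measured step is available to guide the next change.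

Compound 4 `Oc1cccc(-c2cc(-c3ccccc3)nc(-c3ccccn3)c2)c1` follows from compound 3 by one change: pyridin-2-yl in place of phenyl on an aromatic carbon

With compound 3 giving 0% in this assay, there is no room for a downward move, and nothing among the shown compounds indicates that a pyridin-2-yl in place of phenyl at this position should lift the read-out. The expected step of a number 5 percentage points higher from compound 3 to compound 4 (within the scatter) is therefore none beyond the scatter. Compound 4 is expected to give about 5% in this assay, estimated to lie between 0% and 20%.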

Compound 4, a percentage reported as inhibition, at one concentration (the size of the read-out at that concentration, not a potency): 2.8%
Estimate against measurement, compound 4: 2.2 percentage points above; measured number inside the range.
By their numbers in this assay, from the lowest: compounds 3 and 4 (each within the scatter of the next); then compound 2.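

In this assay, among these compounds, the first measured step reads a number 2.8 percentage points higher from compound 3 to compound 4 (within the scatter), so pyridin-2-yl in place of phenyl on this aromatic carbon, next to the ring nitrogen, does not separate the two compounds. Bringing in one hydrogen-bond acceptor at this position therefore gives no read-out distinguishable from that of compound 3, and both compounds stay far from any clear effect at the one concentration tested. No supporting data bear on this result.

Open, as far as these compounds go, is whether any group at this position can lift the read-out, for instance pyridin-4-yl, an aminophenyl group or a carboxylic acid on the phenyl ring. Also open, from the compounds shown here alone, is what the 3-hydroxyphenyl group, shared by compound 3 and compound 4, contributes, which a 3-aminophenyl group in its place could test.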